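Amide nitrogen substituent variation on a sulfonamide acetamide core

The source may report more compounds than this note shows. Statements on the series, on what has been measured and on what is new or still open speak of the compounds shown alone.

Compound 1 `COc1ccc(CNC(=O)CN(c2cc(Cl)ccc2OC)S(=O)(=O)c2ccccc2)cc1`: in a functional assay on SH-SY5Y cells (Homo sapiens), read by MTT assay, with a stated time of 24 h (a higher number here means that more compound is needed for the effect, a lower number that less compound is needed), compound 1 gives > 20000 nM, which is a limit of the assay and not a number.
Compound 2 `CCCNC(=O)CN(c1cc(Cl)ccc1OC)S(=O)(=O)c1ccccc1`: in this assay compound 2 gives > 20000 nM, again a limit and not a number.

Compound 1 therefore stands only at a limit on the numbers shown; no value for it is known, and both results shown sit at the limit of > 20000 nM in this assay, at which 2 of the 2 values shown sit. Among the compounds with values here, the single measured step, a step that the two limits leave unreadable from compound 1 to compound 2, has limits at both ends, so its size cannot be read. Compound 3 `COc1ccc(NC(=O)CN(c2cc(Cl)ccc2OC)S(=O)(=O)c2ccccc2)cc1` differs from compound 1 by 4-methoxyphenyl in place of 4-methoxybenzyl on an amide-type nitrogen. Within the data shown here, no measured step bears on this change: the only step available concerns a different position and is itself unreadable. With both measured compounds at the limit, compound 3 is expected to remain at the limit as well, and the step that the limit leaves unreadable from compound 1 to compound 3 is estimated as none beyond the scatter. For compound 3 the estimate in this assay is 30000 nM, with an expected range from 10000 nM to 100000 nM.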

Compound 3, half-maximal effective concentration: 16200 nM
Beside the measured number, compound 3's estimate is 1.9-fold (0.27 log units) above it; the measured number falls inside the stated range.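

Within the data shown here, with 4-methoxyphenyl on the amide-type nitrogen, compound 3 gives 16200 nM in this assay, the only value shown so far that is a number and not a limit of the assay, so this position can give a readable result. Against 4-methoxybenzyl the change reads as an at least 1.2-fold lower number from compound 1 to compound 3 (0.09 log units; that floor lies within the scatter), and against propyl it reads as an at least 1.2-fold lower number from compound 2 to compound 3 (0.09 log units; that floor lies within the scatter); each is only a floor, and neither floor shows a change beyond the scatter, while the step between the two compounds at the limit cannot be read. The series therefore gives a first number at this position but no measured size for either change, and the other two results remain limits: the limit of > 20000 nM in this assay, at which 2 of the 3 values shown sit.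

As far as these compounds go, how far compound 1 and compound 2 actually lie from compound 3 remains open, and with it whether replacing 4-methoxybenzyl with 4-methoxyphenyl has any real effect on the number. Also open, from the compounds shown here alone, is how the number responds on this amide-type nitrogen to an unsubstituted phenyl, a longer chain, an amine or a carboxylic acid.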